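Swapping chloro for amino on a chlorinated purine-like core

A few compounds are considered here, and "the series" means these few. Any claim that something is new, unique, unknown or untested is made for them only; others in the source may bear on it.

Measured in a functional assay on OVCAR-3 cells (Homo sapiens) for cytotoxicity, read by sulforhodamine B assay, with a stated time of 48 h; a higher number here means that more compound is tolerated, a lower number that less compound is tolerated:
compound 1, `Nc1nc(Cl)c2ncn(Cc3ccc(CCl)cc3)c2n1`, gives 22900 nM;
compound 2, `ClCc1cccc(Cn2cnc3c(Cl)nc(Cl)nc32)c1`, gives 6450 nM;
compound 3, `ClCc1ccc(Cn2cnc3c(Cl)nc(Cl)nc32)cc1`, gives 9550 nM.

Compound 1 and compound 3 differ in one place: amino in place of chloro on an aromatic carbon. That change gave a 2.4-fold higher number from compound 3 to compound 1 (0.38 log units; beyond the scatter). Compound 2 and compound 3 have the same atoms joined differently, and the difference between the two cores is not broken down here; their two values lie within the usual scatter of each other.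

Compound 4, `Nc1nc(Cl)c2ncn(Cc3cccc(CCl)c3)c2n1`, has not yet been measured. It differs from compound 2 by the same change: amino in place of chloro on an aromatic carbon. The step from compound 2 to compound 4 is expected to be a 2.4-fold higher number from compound 2 to compound 4 (0.38 log units; beyond the scatter), because the same change gave a 2.4-fold higher number from compound 3 to compound 1 (0.38 log units; beyond the scatter). Compound 4 is therefore estimated at 15500 nM in this assay, most likely between 7000 nM and 35000 nM.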

Compound 4, concentration lethal to 50% of the cells: 5490 nM
Compound 4: middle estimate off by 2.8-fold (0.45 log units), on the high side; the whole stated range lies above it.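

Putting amino in place of chloro gave a 1.2-fold lower number from compound 2 to compound 4 (0.07 log units; within the scatter) in this assay, so on this core the change has no effect that can be told from the scatter. The step therefore did not carry over unchanged from one core to the other: the same change on two cores in this assay, a 2.4-fold higher number (0.38 log units; beyond the scatter) from compound 3 to compound 1 and a 1.2-fold lower number (0.07 log units; within the scatter) from compound 2 to compound 4, 2.8-fold (0.45 log units) apart, beyond the scatter of two such steps

For the compounds shown here, with only two pairs, this shows that the size of the step can differ between these two cores, but it does not show why, or what the step would be on any further core.

The compounds shown leave open how a hydroxyl or methylamino group would compare with amino at the same place. They also leave open what would happen if the chloromethyl group gave way to a plain methyl group or a longer chain.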